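A Benzofuran in Place of a Chlorofuran on the Core

This account rests on a few compounds, and the source may have more. Where it says the series, first, only, none or still open, it means among the compounds named here.

Measured so far:
- compound 1, `Nc1nc(-c2ccc(C(F)F)o2)nc2sc(CN3CCC(F)CC3)cc12`: 1670 nM
- compound 2, `Nc1nc(-c2ccc(Cl)o2)nc2sc(CN3CCC(F)CC3)cc12`: 1080 nM

Both compounds were tested in an assay on CHO-K1 cells for antagonist activity at adenosine receptor A1 (Homo sapiens), read by a beta-galactosidase reporter, with stated times of 15 min and 6 h; a higher number here means a weaker inhibitor, a lower number a stronger inhibitor. Going by the values given here, compound 2 gives 1080 nM, the lower of the two numbers, but the only step that separates it from compound 1, a 1.5-fold lower number from compound 1 to compound 2 (0.19 log units; within the scatter), lies within the usual scatter, so the two compounds cannot be told apart on these numbers.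

Compound 3, `Nc1nc(-c2cc3ccccc3o2)nc2sc(CN3CCC(F)CC3)cc12`, has not yet been measured. It differs from compound 2 in one place: 1-benzofuran-2-yl in place of 5-chlorofuran-2-yl on an aromatic carbon. Among the compounds with values here, the single measured step, a 1.5-fold lower number from compound 1 to compound 2 (0.19 log units; within the scatter), swaps one small group on the furan ring for another and says nothing about fusing a benzene ring onto it. Within the data shown here, there is therefore no measured step that bears directly on this change, and the expectation rests on the shared core alone.

In this assay compound 3 is expected to give about 800 nM, with a range from 200 nM to 3200 nM, which means an expected step of a 1.4-fold lower number from compound 2 to compound 3 (0.13 log units; within the scatter), not clearly beyond the scatter in either direction.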

Compound 3, inhibition constant: 630 nM
Estimate against measurement, compound 3: 1.3-fold (0.10 log units) above; the measured number falls inside the stated range.
By their numbers in this assay, from the lowest: compounds 3, 2 and 1 (each within the scatter of the next, the first and the last beyond it).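

In this assay, the step from the 5-chlorofuran-2-yl group to the larger 1-benzofuran-2-yl group, a 1.7-fold lower number from compound 2 to compound 3 (0.23 log units; within the scatter), does not separate the two compounds, so a benzene ring fused onto the furan shows no clear loss or gain at this position on the shared core. Going by these compounds alone, the comparison with the 5-(difluoromethyl)furan-2-yl group gives a 2.7-fold lower number from compound 1 to compound 3 (0.42 log units; beyond the scatter), the first step in this short series that rises above the scatter, although it is only modest in size and the number for compound 3 stays close to that for compound 2. Nothing in these data gives a reason for either step.

All three groups at this aromatic carbon between two ring nitrogen atoms are built on a furan, so a phenyl ring with no ring oxygen, or a small open group such as an amine or a methoxy group, would show how much the furan itself matters. The three compounds also keep the same fluorinated ring on the other side of the core, and a morpholine there would test whether the same order of numbers holds with a different amine.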